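An aryl exchange on the amine-bearing ring, from compound 1 to compound 3

The source may hold more compounds than are shown below. What is called first, only, known or untested is meant among the compounds shown, and "the series" means these compounds.

Measured compounds:
compound 1, `CCC1(CCCCN2CCN(c3cccc(Cl)c3)CC2)C(=O)Nc2ccccc21`, gives > 10 mg/kg
compound 2, `CCC1(CCCCN2CCN(c3cccc(Cl)c3)CC2)C(=O)Nc2cc(F)c(Cl)cc21`, gives "not determined" (no result reported)

The study measures minimum effective dose in a functional assay on the whole organism (strain Wistar) with Rattus norvegicus as the target, with a stated time of 30 min; a lower number here means that less compound is needed, a higher number that more compound is needed for the effect. Compound 1 reaches only > 10 mg/kg in this assay, which is a limit of the assay and not a number. Compound 2 carries no result in this assay, so it adds nothing to the picture. Within the data shown here, compound 1 therefore stands at the limit of > 10 mg/kg in this assay, at which 1 of the 2 values shown sits, and the one further entry is without a single number; no step between measured compounds can be drawn.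

Compound 3, `CCC1(CCCCN2CCN(c3ccc(F)cc3)CC2)C(=O)Nc2ccccc21`, is the next compound to be tested in this assay. It differs from compound 1 in one place: 4-fluorophenyl in place of 3-chlorophenyl on an amine nitrogen in a ring. Among the measured compounds shown here, with no measured step to lean on, the size of the step in this assay cannot be read from the data; the expectation is a step of no more than the usual scatter, in no fixed direction.

On that basis compound 3 is expected to give about 10 mg/kg in this assay, with a range from 3 mg/kg to 30 mg/kg. The step that this estimate means, a number no higher from compound 1 to compound 3 (the limit leaves the size open), is expected to stay within the scatter.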

Compound 3, minimum effective dose: 10 mg/kg
The estimate for compound 3 equals the measured number at the digits printed; measured number inside the range.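

In this assay, compound 3 gives 10 mg/kg, the first single number among the compounds shown, so the amine nitrogen in a ring can carry 4-fluorophenyl and still give a readable dose. For compound 1, the entry of > 10 mg/kg is a limit of the assay and not a number. Putting 4-fluorophenyl in place of 3-chlorophenyl amounts to a number no higher from compound 1 to compound 3 (the limit leaves the size open), and the change in dose cannot be sized because compound 1 stays at that limit: the limit of > 10 mg/kg in this assay, at which 1 of the 3 values shown sits.

The compounds shown leave open whether the result follows the halogen itself or its place on the phenyl ring; 4-chlorophenyl or 3-fluorophenyl on the same nitrogen would separate the two, and plain phenyl would show whether a halogen is needed at all. Also open, from the compounds shown here alone, is how the core responds to substitution, since compound 2, with fluorine and chlorine on the core, has no result, and how a shorter or longer chain in place of the four-carbon link to the amine would read in this assay.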